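The source may hold more compounds than are shown below. What is called first, only, known or untested is meant among the compounds shown, and "the series" means these compounds.

Series notes, two measured compounds and one pending.

Compound 1 `Cc1ccc(COc2ccc3c(c2)C(C)(C)C(=O)N3)cc1` carries a methyl-substituted benzyl ether on the shared core; in an assay on cells for inhibition of Amine oxidase [flavin-containing] B (Homo sapiens), read by fluorescence, with stated times of 30 min and 15 min, tested at 1 uM (a higher number here means more inhibition at the concentration tested (going by the name of the read-out), a lower number less inhibition), compound 1 is reported as "not active" (no number reported), with no number given. Compound 2 `CC1(C)C(=O)Nc2ccc(OCc3cccc(Cl)c3)cc21` replaces the methyl-substituted benzyl group with a chloro-substituted one; in this assay compound 2 gives 21.1%. Within the data shown here, compound 2 therefore stands as the only compound with a number in this assay; compound 1 has only the qualitative report beside it, so no step between the two can be sized.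

Compound 3 `CC1(C)C(=O)Nc2ccc(OCc3ccc(Cl)c(Cl)c3)cc21` is the next entry, not yet measured in this assay. Relative to compound 2 the change is chloro in place of hydrogen on an aromatic carbon. Because compound 2 gives 21.1% as the sole reference point, the expectation for the step from compound 2 to compound 3 in this assay rests on that one value alone: a small rise of a number 8.9 percentage points higher from compound 2 to compound 3 (within the scatter) is expected, of a size that sits within or only just beyond the usual scatter of repeated measurements. Accordingly compound 3 is estimated at 30% in this assay, with a range from 10% to 55%.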

Compound 3, a percentage reported as inhibition, at one concentration (the size of the read-out at that concentration, not a potency): 28.8%
Beside the measured number, compound 3's estimate is 1.2 percentage points above it; the range from low to high includes it.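

In this assay, among these compounds, chloro in place of hydrogen on an aromatic carbon, ortho to a chloro group and para to a large group, gives a number 7.7 percentage points higher from compound 2 to compound 3 (within the scatter) as the first step that can be sized. This step lies within the scatter, so the added chloro at this position leaves the reading indistinguishable from that of the singly chlorinated benzyl ether, and no order between the two compounds can be claimed. No measurement is available that bears on this result.

On these data alone, whether another group at this position, such as a methoxy, an amine or a carboxylic acid, would move the reading beyond the scatter remains open. Steps to or from compound 1 cannot be read, as it has no number, so the methyl-substituted benzyl ether cannot be placed against the chloro-substituted ones, and what a reading well above those of compound 2 and compound 3 would need also remains open.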